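This account rests on a few compounds, and the source may have more. Where it says the series, first, only, none or still open, it means among the compounds named here.

Compound 1 `Cc1cccc(NC(=O)CSc2nnc(-c3ccoc3C)n2Cc2ccco2)c1C` is the starting point. In a functional assay on CHO cells for antagonist activity at Orexin/Hypocretin receptor type 1 (Homo sapiens), read by FLIPR and calcium flux (a higher number here means a weaker inhibitor, a lower number a stronger inhibitor), compound 1 gives > 15800 nM, which is a limit of the assay and not a number. Among the compounds with values here, compound 2 `Cc1occc1-c1nnc(SCC(=O)Nc2cccc(Cl)c2)n1Cc1ccco1` gives 2000 nM in this assay; the step of an at least 7.9-fold lower number from compound 1 to compound 2 (0.89 log units; beyond the scatter) is the only measured change from compound 1, and its size rests on (the limit of > 15800 nM in this assay, at which 1 of the 2 values shown sits). Compound 3 `Cc1occc1-c1nnc(SCC(=O)Nc2ccc(N(C)C)cc2)n1Cc1ccco1` differs from compound 1 by 4-(dimethylamino)phenyl in place of 2,3-dimethylphenyl on an amide-type nitrogen. That measured step replaces the same group with a different one, so it bears on compound 3 only loosely. For compound 3 a number of 9000 nM is estimated, between 2000 nM and 30000 nM. This would mean an expected step of an at least 1.7-fold lower number from compound 1 to compound 3 (0.24 log units; that floor lies within the scatter).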

Compound 3, inhibition constant: 794 nM
Compound 3: the middle estimate sits 11-fold (1.05 log units) above what was measured; the whole stated range lies above it.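

Putting 4-(dimethylamino)phenyl in place of 3-chlorophenyl on the amide-type nitrogen gives a 2.5-fold lower number from compound 2 to compound 3 (0.40 log units; beyond the scatter) in this assay, so compound 3 is the strongest of the three and this position accepts a group carrying a nitrogen. The change from 2,3-dimethylphenyl gives an at least 19-fold lower number from compound 1 to compound 3 (1.29 log units; beyond the scatter), and that size is only a floor: the limit of > 15800 nM in this assay, at which 1 of the 3 values shown sits.

The compounds shown leave open whether the lower number comes from the dimethylamino group itself or from where it sits on the phenyl ring. They also leave open whether a plain amino group or a methoxy group would serve in its place.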